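Stretching a Short Chain: From Compound 3 to Compound 4

The source may report more compounds than this note shows. Statements on the series, on what has been measured and on what is new or still open speak of the compounds shown alone.

Of the compounds shown here, three that share one core have been tested in an assay on isolated protein (adrenal medulla) for inhibition of Dopamine beta-hydroxylase (Bos taurus); on this read-out higher numbers stand for weaker inhibition and lower numbers for stronger inhibition. Compound 1 `Nc1ncn(Cc2ccc(Cl)cc2Cl)c2ncnc1-2` gives 200 ug/mL in this assay. Compound 2 `Nc1ncn(Cc2ccccc2[N+](=O)[O-])c2ncnc1-2` gives 200 ug/mL in this assay. Compound 3 `CCn1cnc(N)c2ncnc1-2` carries only a short ethyl chain where the other two carry a larger group. For compound 3, this assay reports no number but only a limit, > 200 ug/mL, which marks the edge of what the measurement can resolve. Compound 3 therefore sits at the limit of > 200 ug/mL in this assay, at which 1 of the 3 values shown sits.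

Compound 4 `CCCCCCn1cnc(N)c2ncnc1-2` differs from compound 3 by a single change: butyl in place of hydrogen on a saturated chain carbon, two bonds along the chain from an aromatic nitrogen. Among the compounds with values here, none of the three measured compounds differ from one another by a comparable single change, so there is no measured step to lean on, and the size of the effect can only be estimated.

Since compound 3 gives only a limit in this assay, the most likely outcome for compound 4 is a reading close to that same limit, with the longer chain perhaps bringing inhibition just into the measurable range; the expected shift is a number no higher from compound 3 to compound 4 (the limit leaves the size open). Compound 4 is expected to give about 200 ug/mL in this assay, with a plausible range from 60 ug/mL to 400 ug/mL.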

Compound 4, half-maximal inhibitory concentration: 1 ug/mL
Beside the measured number, compound 4's estimate is 200-fold (2.30 log units) above it; measured number below the stated range.
By their numbers in this assay, from the lowest: compound 4; then compounds 1 and 2 (each within the scatter of the next).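

In this assay, the read-out shows an at least 200-fold lower number from compound 3 to compound 4 (2.30 log units; beyond the scatter), so this position, on a saturated chain carbon two bonds along the chain from an aromatic nitrogen, can carry a change that moves the result well beyond the usual scatter. Within the data shown here, the earlier compounds could not show this, as no two of them differ in one place; butyl in place of hydrogen is the first single change here whose effect can be read at all. Compound 3 stands at a limit and not at a number, so the step gives only a floor for the effect and its true size stays open: the limit of > 200 ug/mL in this assay, at which 1 of the 4 values shown sits.

A single step cannot tell whether the number keeps falling as the chain grows, so a longer chain such as octyl could continue the trend, match it or reverse it. Nor do the compounds shown tell whether a chain ending in an amine or a carboxylic acid would read like compound 4, at 1 ug/mL, or whether the gain belongs to plain carbon chains alone.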